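The source may report more compounds than this note shows. Statements on the series, on what has been measured and on what is new or still open speak of the compounds shown alone.

Measured so far:
Compound 1, `CCn1c(C(=O)N(C)CCC#N)ccc1C(CC)(CC)c1ccc(OCC(=O)C(C)(C)C)c(C)c1`, gives 9800 nM in an assay on HL-60 cells for agonist activity at vitamin D3 receptor (Homo sapiens), read by microscopy, with a stated time of 96 h; on this read-out lower numbers stand for an effect already at smaller amounts and higher numbers for an effect only at larger amounts of compound.
Compound 2, `CCn1c(C(=O)N(C)CCC#N)ccc1C(CC)(CC)c1ccc(OCC(O)C(C)(C)C)c(C)c1`, gives 1960 nM in this assay.

Among these two numbers compound 2 stands lowest, and compound 1 is its only neighbour, separated by a 5.0-fold lower number from compound 1 to compound 2 (0.70 log units; beyond the scatter). Compound 3, `CCn1c(C(=O)Nc2cccc(C(F)(F)F)c2)ccc1C(CC)(CC)c1ccc(OCC(O)C(C)(C)C)c(C)c1`, has not yet been measured. It differs from compound 2 at the amide: (3-(trifluoromethyl)phenyl)amino in place of (2-cyanoethyl)(methyl)amino on a carbonyl carbon. Going by the values given here, the one measured step concerns the group on a saturated chain carbon bound to an oxygen on an aromatic ring, at the other end of the shared core, so no measured step speaks to a change at the carbonyl carbon. The expectation for this assay therefore rests on compound 2 with its 1960 nM alone. With wide uncertainty, the step is expected to be a 1.0-fold higher number from compound 2 to compound 3 (0.01 log units; within the scatter). Compound 3 is estimated at 2000 nM, between 400 nM and 10000 nM.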

Compound 3, half-maximal effective concentration: > 50000 nM
Compound 3 ended at the assay's limit (the forecaster's own chance of this, stated with the estimate: 10%); middle value at least 25-fold (1.39 log units) from the limit.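

In this assay, the group on the carbonyl carbon proved to matter: (3-(trifluoromethyl)phenyl)amino in place of (2-cyanoethyl)(methyl)amino gave an at least 25-fold higher number from compound 2 to compound 3 (1.40 log units; beyond the scatter). The earlier step, a 5.0-fold lower number from compound 1 to compound 2 (0.70 log units; beyond the scatter), spoke only to the group on a saturated chain carbon bound to an oxygen on an aromatic ring, and this change at the carbonyl carbon moved the read-out by more than that step did. The reading for compound 3 is a limit of the assay and not a number, so the full size of this step stays unknown: the limit of > 50000 nM in this assay, at which 1 of the 3 values shown sits.

The change brings in an aromatic ring, a trifluoromethyl group and an amide hydrogen and removes the nitrile all at once, and the compounds shown do not separate these parts. From the compounds shown here alone, it also remains open how a plain phenylamino group without trifluoromethyl, or a dimethylamino group, would read on the same carbonyl carbon.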